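Swapping a nitrile for a propyl chain

The compounds below may be only part of what the source reports. "The series", "measured", "known", "first", "only" and "open" are said of these compounds alone.

Within the data shown here, compound 2 `N#Cc1ccc(C(=O)Nc2cccc(-c3oc4cc(-c5ccc(F)cc5)ccc4c(=O)c3O)c2)cc1` is one of two compounds measured in a functional assay on MCF7 cells (Homo sapiens) for antiproliferative activity, read by CCK-8 assay, with a stated time of 72 h; a lower number here means a stronger inhibitor, a higher number a weaker inhibitor; compound 2 gives 2660 nM, and compound 1 `O=C(Nc1cccc(-c2oc3cc(-c4ccc(F)cc4)ccc3c(=O)c2O)c1)c1ccc(Cl)nc1` gives 2890 nM, the two numbers lying within the scatter of each other. Among the measured compounds shown here, the only step recorded, a 1.1-fold lower number from compound 1 to compound 2 (0.04 log units; within the scatter), is within the scatter. Compound 3 `CCCc1ccc(C(=O)Nc2cccc(-c3oc4cc(-c5ccc(F)cc5)ccc4c(=O)c3O)c2)cc1` differs from compound 2 by propyl in place of cyano on an aromatic carbon. For the measured compounds named here, no measured step covers this change; the one step known at this part of the structure did not move the number. The expected step is a 1.0-fold higher number from compound 2 to compound 3 (0.01 log units; within the scatter). The estimate for compound 3 is 2700 nM, with a range from 1300 nM to 5600 nM.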

Compound 3, half-maximal inhibitory concentration: 36800 nM
Estimate against measurement, compound 3: 14-fold (1.13 log units) below; the measured number lies above the stated range.
By their numbers in this assay, from the lowest: compounds 2 and 1 (each within the scatter of the next); then compound 3.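

The earlier step suggested that this part of the structure tolerates change, but the change to propyl does not fit that picture: this assay shows a 14-fold higher number from compound 2 to compound 3 (1.14 log units; beyond the scatter) for this one substitution. The comparison with the 6-chloropyridin-3-yl amide agrees, with a 13-fold higher number from compound 1 to compound 3 (1.10 log units; beyond the scatter) on the same carbonyl carbon. So here the group on the ring matters, and a propyl chain is clearly worse than cyano. Nothing measured here gives a reason for this.

From the compounds shown here alone, whether a shorter chain such as methyl, a longer chain such as butyl, or an amine would track with propyl or with cyano remains open.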